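Two inactive amides and a methylsulfanylphenyl variant

This account rests on a few compounds, and the source may have more. Where it says the series, first, only, none or still open, it means among the compounds named here.

Compound 1 `Cc1cccc(NC(=O)c2cccc(/C=C3\CC(=O)N(c4ccccc4)C3=O)c2)c1`: > 100000 nM
Compound 2 `O=C(NCC1CCCCC1)c1cccc(/C=C2\CC(=O)N(c3ccccc3)C2=O)c1`: > 100000 nM

Both measured compounds were tested in an ADME assay on HCT-116 cells (Homo sapiens) for cytotoxicity, read by MTT assay, with a stated time of 72 h; on this read-out higher numbers stand for weaker inhibition and lower numbers for stronger inhibition. The value of compound 1 is a limit of the assay and not a number: compound 1 gave > 100000 nM. The value of compound 2 is likewise a limit: compound 2 gave > 100000 nM. Going by the values given here, the only measured step, a step that the two limits leave unreadable from compound 1 to compound 2, cannot be read in size because both of its ends sit at the limit of > 100000 nM in this assay, at which 2 of the 2 values shown sit. Compound 3 `CSc1cccc(NC(=O)c2cccc(/C=C3\CC(=O)N(c4ccccc4)C3=O)c2)c1` differs from compound 2 by 3-(methylsulfanyl)phenyl in place of cyclohexylmethyl on an amide-type nitrogen. Among the compounds with values here, no measured step other than the unreadable one bears on this change, so nothing in the data points to a readable gain or loss. With compound 2 at the limit, compound 3 is expected to stay at the limit too, and the step that the limit leaves unreadable from compound 2 to compound 3 is expected to be no readable change. The estimate for compound 3 is 150000 nM, with a range from 50000 nM to 500000 nM.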

Compound 3, half-maximal inhibitory concentration: 65200 nM
Beside the measured number, compound 3's estimate is 2.3-fold (0.36 log units) above it; the measured number falls inside the stated range.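

Compound 3 is the only one of the three to give a number rather than a limit in this assay, so the amide-type nitrogen can carry a group that brings a readable value. Against the cyclohexylmethyl amide, the result is an at least 1.5-fold lower number from compound 2 to compound 3 (0.18 log units; that floor lies within the scatter), and the change of methyl to methylsulfanyl on an aromatic carbon gives an at least 1.5-fold lower number from compound 1 to compound 3 (0.18 log units; that floor lies within the scatter). Both steps are only floors, so the real gaps may be larger, but the data cannot yet show a difference beyond the scatter, and the other two compounds remain at a limit: the limit of > 100000 nM in this assay, at which 2 of the 3 values shown sit.

Going by these compounds, it remains open what a methoxy group, a chlorine atom or a dimethylamino group would give on that aromatic carbon in place of methylsulfanyl. On these data alone, it is also open whether a longer chain carrying an amine or a carboxylic acid on the amide-type nitrogen would lower the number further.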